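The compounds below may be only part of what the source reports. "The series", "measured", "known", "first", "only" and "open" are said of these compounds alone.

Working notes on the series: in a functional assay on HeLa cells (Homo sapiens) for antiproliferative activity, read by sulforhodamine B assay (a higher number here means a weaker inhibitor of growth, a lower number a stronger inhibitor of growth), only two results exist so far. Compound 1 `CC[C@@H]1O[C@H](COCc2ccccc2)[C@@H](OCc2ccccc2)[C@H](OCc2ccccc2)[C@H]1OC(C)=O` reads > 50000 nM as a limit of the assay and not a number. Compound 2 `CCC[C@@H]1O[C@H](COCc2ccc(F)cc2)[C@@H](OCc2ccc(F)cc2)[C@H](OCc2ccc(F)cc2)[C@H]1O` gives 12300 nM as the only actual number shown, so it has no measured neighbour against which its place can be graded.

Next comes compound 3 `CCC[C@H]1O[C@H](COCc2ccc(F)cc2)[C@@H](OCc2ccc(F)cc2)[C@H](OCc2ccc(F)cc2)[C@H]1O` as the epimer of compound 2. The difference is the two compounds have the same atoms and bonds and differ only in configuration as drawn: 1 of 5 stereo elements differ; a stereocentre at a saturated ring carbon is drawn S in compound 2 and R in compound 3 with the same atoms and bonds in both, and a stereocentre at a saturated ring carbon is drawn S in compound 2 and R in compound 3.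

Among the compounds with values here, no measured pair shows what such an inversion does in this assay and so no direction can be argued from the data. The working expectation is no step beyond the scatter, starting from compound 2 at 12300 nM with a wide margin on both sides. The estimated move is a 1.2-fold higher number from compound 2 to compound 3 (0.09 log units; within the scatter) and is expected to be small. Compound 3 is estimated at 15000 nM with an expected range from 5000 nM to 45000 nM for this first reading.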

Compound 3, concentration for 50% growth inhibition: 5600 nM
The estimate for compound 3 lay 2.7-fold (0.43 log units) above the measured number; measured number inside the range.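

In this assay, within the data shown here, inverting one stereocentre at a saturated ring carbon from S to R gives a 2.2-fold lower number from compound 2 to compound 3 (0.34 log units; beyond the scatter), the first step that can be read at all. This shows that configuration at this centre alone can move the number modestly beyond the scatter, with nothing entering or leaving the structure, a reading that rests on the following: the fact that compounds 2 and 3 differ only in the configuration as drawn. Compound 1 remains outside any grading as a limit of the assay and not a number: the limit of > 50000 nM in this assay, at which 1 of the 3 values shown sits.

This single pair leaves open whether the same inversion gives a step of similar size and direction with other groups on the shared core, and what inversion at the other stereocentres would do. It also leaves open whether an amine or a carboxylic acid on the shared core, or a longer chain, would move the number further in this assay than this change in configuration does.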